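Amide nitrogen substituent change on a shared core

The source may report more compounds than this note shows. Statements on the series, on what has been measured and on what is new or still open speak of the compounds shown alone.

Three members of the series have been tested in a functional assay on A549 cells (Homo sapiens) for cytotoxicity, read by MTT assay, with a stated time of 24 h; on this read-out lower numbers stand for stronger inhibition and higher numbers for weaker inhibition. Compound 1, `C=CC1=C(C(=O)NCc2ccccc2)C(c2ccc(Cl)c(Cl)c2)OC1`, gives in this assay only a limit of the assay, > 100000 nM. Compound 2, `C=CC1=C(C(=O)NCCC)C(c2ccc(OC)c(OC)c2)OC1`, likewise returns in this assay a limit, > 100000 nM. Compound 3, `C=CC1=C(C(=O)Nc2ccc(C)cc2)C(c2ccc(F)cc2)OC1`, also sits in this assay at a limit, > 100000 nM. Compound 3 therefore stands where every measured member stands, at the limit of > 100000 nM in this assay, at which 3 of the 3 values shown sit, and no ordering of compounds 1, 2 and 3 can be drawn from these numbers.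

Compound 4, `C=CC1=C(C(=O)NCc2ccc(C)cc2)C(c2ccc(F)cc2)OC1`, is the next member. It differs from compound 3 by 4-methylbenzyl in place of 4-methylphenyl on an amide-type nitrogen. Going by the values given here, no step between measured compounds is available for comparison here. Compound 1 is the closest tested relative of compound 4, and because compound 1 sits at the limit > 100000 nM, no movement beyond the scatter in either direction is expected. The step expected here, a step that the limit leaves unreadable from compound 3 to compound 4, is thus essentially none. Compound 4 is estimated to give 150000 nM in this assay, within an expected range from 50000 nM to 500000 nM, and most likely it will again be reported as a limit rather than a number.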

Compound 4, half-maximal inhibitory concentration: > 100000 nM
Compound 4 gave a limit, no number; the forecaster's own chance of this, stated with the estimate: 88%; the middle value does not contradict the limit.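

Compound 3 and compound 4 both sit at a limit, not a number, in this assay, so no step can be read between them, and the change on the amide-type nitrogen stays unresolved: the limit of > 100000 nM in this assay, at which 4 of the 4 values shown sit.

The compounds shown leave open whether any change on the shared core would bring a readable value in this assay.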